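This account rests on a few compounds, and the source may have more. Where it says the series, first, only, none or still open, it means among the compounds named here.

Working notes on the series.

In a functional assay on MCF7 cells (Homo sapiens) for cytotoxicity, read by MTT assay, with a stated time of 72 h (a lower number here means a stronger inhibitor, a higher number a weaker inhibitor), compound 3 `CC(C)NC(=O)N1CCN(C(=S)SCc2cn(Cc3ccc(F)cc3)nn2)CC1` gives 1660 nM, the lowest of the three numbers in hand. Among the measured compounds shown here, compound 2 `CCNC(=O)N1CCN(C(=S)SCc2cn(Cc3ccc(F)cc3)nn2)CC1` gives 3660 nM in this assay, and the only single-point step available, a 2.2-fold lower number from compound 2 to compound 3 (0.34 log units; beyond the scatter), is a modest one. Compound 1 `O=C(NC1CCCCC1)N1CCN(C(=S)SCc2cn(Cc3ccccc3F)nn2)CC1` gives 85000 nM in this assay; it already carries the cyclohexyl group but differs from compound 3 in a second place as well, so its number cannot be read as a step.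

Compound 4 `O=C(NC1CCCCC1)N1CCN(C(=S)SCc2cn(Cc3ccc(F)cc3)nn2)CC1` is not yet measured. It differs from compound 3 by cyclohexyl in place of isopropyl on an amide-type nitrogen. For the measured compounds named here, the one measured step, from ethyl to isopropyl, moved the number down modestly; growing the same group further to cyclohexyl has no direct precedent, and the high number of compound 1 85000 nM is confounded. The expectation for compound 4 is therefore no change beyond the scatter, a 1.1-fold higher number from compound 3 to compound 4 (0.04 log units; within the scatter), with compound 4 estimated at 1800 nM in this assay, within a range of 500 nM to 7000 nM.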

Compound 4, half-maximal inhibitory concentration: > 128000 nM
Compound 4: no number, only a limit; the forecaster's own chance of this, stated with the estimate: 2%; middle value at least 71-fold (1.85 log units) away from the limit.
By their numbers in this assay, from the lowest: compound 3; then compound 2; then compound 1. At a limit, above all of these: compound 4.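

Compound 4 gives no number, only a limit: the limit of > 128000 nM in this assay, at which 1 of the 4 values shown sits.

On the amide-type nitrogen the earlier step gave no warning of a cliff: ethyl to isopropyl brought a 2.2-fold lower number from compound 2 to compound 3 (0.34 log units; beyond the scatter), while in this assay cyclohexyl in place of isopropyl brings an at least 77-fold higher number from compound 3 to compound 4 (1.88 log units; beyond the scatter), and cyclohexyl in place of ethyl brings an at least 34-fold higher number from compound 2 to compound 4 (1.54 log units; beyond the scatter). The high number of compound 1 now has a closer match, since the change of 2-fluorophenyl to 4-fluorophenyl gives an at least 1.5-fold higher number from compound 1 to compound 4 (0.17 log units; that floor lies within the scatter), a floor within the scatter, so the two fluorophenyl groups cannot be ordered.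

Open, on these data alone, is where on the way from isopropyl to cyclohexyl the number climbs, which a cyclobutyl or cyclopentyl group on the same nitrogen would help to place. Also open, as far as these compounds go, is whether an open-chain hexyl group, with no ring, behaves like cyclohexyl.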